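A few compounds are considered here, and "the series" means these few. Any claim that something is new, unique, unknown or untested is made for them only; others in the source may bear on it.

Measured so far:
compound 1 `COC(=O)/C(=C\c1ccc(OC(=O)c2ccc(OC)cc2)cc1)Sc1ccnc2cc(Cl)ccc12` – 11000 nM
compound 2 `COC(=O)/C(=C\c1ccc(OC(=O)c2cccc(OC)c2)cc1)Sc1ccnc2cc(Cl)ccc12` – 33300 nM

Within the data shown here, in a functional assay on Jurkat E6.1 cells (Homo sapiens) for cytotoxicity, read by MTT assay, with a stated time of 24 h (on this read-out lower numbers stand for stronger inhibition and higher numbers for weaker inhibition), compound 2 gives the higher of the two numbers; compound 1 gives 11000 nM, and the step of a 3.0-fold higher number from compound 1 to compound 2 (0.48 log units; beyond the scatter) is the only measured comparison. Compound 3 `COC(=O)/C(=C\c1ccc(OC(=O)c2c(OC)cccc2OC)cc1)Sc1ccnc2cc(Cl)ccc12` is not yet measured. It differs from compound 2 by 2,6-dimethoxyphenyl in place of 3-methoxyphenyl on a carbonyl carbon. Among the measured compounds shown here, the one measured step bears on it only loosely: it shows that moving the single methoxy group on the benzoyl ring shifted the number by a modest amount, but no measured pair shows a second methoxy group or the 2,6-pattern. The expectation for compound 3 is therefore uncertain, leaning toward a number near or somewhat above that of compound 2, with a wide range. Compound 3 is estimated at 30000 nM (range 8000 nM to 100000 nM), an expected step of a 1.1-fold lower number from compound 2 to compound 3 (0.05 log units; within the scatter).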

Compound 3, half-maximal inhibitory concentration: 37500 nM
For compound 3 the middle estimate is 1.3-fold (0.10 log units) below the measured one, within the range that was stated.
By their numbers in this assay, from the lowest: compound 1; then compounds 2 and 3 (each within the scatter of the next).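

In this assay, among these compounds, the change to 2,6-dimethoxyphenyl on the carbonyl carbon puts a second methoxy group on this ring for the first time, and the read-out does not separate the two compounds (a 1.1-fold higher number from compound 2 to compound 3 (0.05 log units; within the scatter)). Set against 4-methoxyphenyl, the same group gives a clear step (a 3.4-fold higher number from compound 1 to compound 3 (0.53 log units; beyond the scatter)), so among the three compounds only compound 1 stands apart, with compounds 2 and 3 together on the weaker side. Nothing measured here gives a cause for this grouping.

The compounds shown leave open how an amine or a carboxylic acid on this ring, or a longer chain such as butoxy in place of methoxy, would read in this assay. They also leave open whether a ring with a single methoxy group and one with two can be told apart anywhere else in this series.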